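Naphthalenyl sulfonamide expected to lower the effective concentration

The source may report more compounds than this note shows. Statements on the series, on what has been measured and on what is new or still open speak of the compounds shown alone.

Compound 2 `Cc1ccccc1S(=O)(=O)NCc1ccc(CNC(=O)c2ccc(F)cc2)cc1` stands highest of the two numbers in an assay on MDA-MB-231 cells for binding affinity to C-X-C chemokine receptor type 4 (Homo sapiens), read by fluorescence and microscopy, with stated times of 10 min and 30 min (on this read-out higher numbers stand for an effect only at larger amounts of compound and lower numbers for an effect already at smaller amounts), where compound 2 gives 100 nM. For the measured compounds named here, its only neighbour, compound 1 `O=C(NCc1ccc(CNS(=O)(=O)c2ccc3c(c2)CCO3)cc1)c1ccc(F)cc1`, gives 10 nM in this assay. Going by the values given here, the single measured step, a 10-fold higher number from compound 1 to compound 2 (1.00 log units; beyond the scatter), replaced a two-ring group on the sulfonyl sulfur by a one-ring group. Compound 3 `O=C(NCc1ccc(CNS(=O)(=O)c2cccc3ccccc23)cc1)c1ccc(F)cc1` runs the other way: naphthalen-1-yl in place of 2-methylphenyl on a sulfonyl sulfur. Among the compounds with values here, only that one step bears on the change, and it points toward a lower number when a second ring returns. Compound 3 is therefore expected to give 25 nM in this assay, within 8 nM to 80 nM. This expectation amounts to a 4.0-fold lower number from compound 2 to compound 3 (0.60 log units; beyond the scatter).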

Compound 3, effective concentration (reported as EC, without a stated level of effect): 1000 nM
The estimate for compound 3 lay 40-fold (1.60 log units) below the measured number; measured number outside the range, above it.
By their numbers in this assay, from the lowest: compound 1; then compound 2; then compound 3.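

At this sulfonyl sulfur a second ring does not by itself bring the number down: in this assay there is a 10-fold higher number from compound 2 to compound 3 (1.00 log units; beyond the scatter) with naphthalen-1-yl in place of 2-methylphenyl. The two groups with two rings stand at opposite ends of the series, with a 100-fold higher number from compound 1 to compound 3 (2.00 log units; beyond the scatter) and compound 2, with its single ring, in the middle, so ring count does not order these compounds. Nothing shown gives a reason for this gap between the two-ring groups. As far as these compounds go, it remains open how naphthalen-2-yl, or a group carrying an amine, would read on the same sulfonyl sulfur.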